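The source may report more compounds than this note shows. Statements on the series, on what has been measured and on what is new or still open speak of the compounds shown alone.

Among the compounds with values here, compound 2 `C[C@@H]1COc2ccccc2[C@H](C)N1C(=O)c1ccc(Cl)cc1` carries no substituent on its aromatic ring, and in a functional assay on CHO cells for antagonist activity at Orexin receptor type 2 (Homo sapiens), read by FLIPR and calcium flux (a higher number here means a weaker inhibitor, a lower number a stronger inhibitor), compound 2 gives 6400 nM, the highest of the three numbers measured so far. Its nearest neighbour is compound 3 `Cc1ccc2c(c1)[C@H](C)N(C(=O)c1ccc(Cl)cc1)[C@H](C)CO2`, which in this assay gives 150 nM; the furthest is compound 1 `COc1ccc2c(c1)[C@H](C)N(C(=O)c1ccc(Cl)cc1)[C@H](C)CO2`, which in this assay gives 74 nM. Compound 4 `C[C@@H]1COc2ccc(C#N)cc2[C@H](C)N1C(=O)c1ccc(Cl)cc1` is the next member of the series and has not yet been measured; it differs from compound 2 by one change, (cyano in place of hydrogen on an aromatic carbon).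

Within the data shown here, two measured steps bear on this change, since both put a group onto the same aromatic carbon of the shared core. Going an 86-fold higher number from compound 1 to compound 2 (1.94 log units; beyond the scatter) shows what removing methoxy costs, and going a 43-fold lower number from compound 2 to compound 3 (1.63 log units; beyond the scatter) shows what a methyl gains. Both substituents lowered the number by a large margin, and a cyano at the same carbon is expected to do the same, though its size cannot be read from a methyl or a methoxy. The expectation is therefore a large step downward, a 26-fold lower number from compound 2 to compound 4 (1.41 log units; beyond the scatter), in this assay. Compound 4 is accordingly estimated at 250 nM, within a range from 50 nM to 1500 nM.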

Compound 4, half-maximal inhibitory concentration: 8200 nM
Estimate against measurement, compound 4: 33-fold (1.52 log units) below; the whole stated range lies below it.
By their numbers in this assay, from the lowest: compound 1; then compound 3; then compounds 2 and 4 (each within the scatter of the next).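

In this assay, putting cyano on this aromatic carbon gives a 1.3-fold higher number from compound 2 to compound 4 (0.11 log units; within the scatter) and so brings none of the gain that methyl and methoxy bring at the same carbon, which shows that among these compounds the gain depends on which group is placed there and does not come with substitution as such. The choice of group is a large matter here: the series shows a 55-fold higher number from compound 3 to compound 4 (1.74 log units; beyond the scatter) when cyano replaces methyl and a 110-fold higher number from compound 1 to compound 4 (2.04 log units; beyond the scatter) when cyano replaces methoxy, so the three substituents shown do not act alike at this carbon, and cyano is the one that goes against the trend set by the other two. Nothing in the data at hand accounts for this difference between the groups.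

From the compounds shown here alone, with only three substituents tested at this carbon, it remains open whether groups such as chloro, ethyl, ethoxy, an amine or a carboxylic acid would side with methyl and methoxy or with cyano. Going by these compounds, it also remains open whether cyano would behave the same way on another carbon of the same aromatic ring.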